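The compounds below may be only part of what the source reports. "The series", "measured", "known", "first", "only" and "open" are said of these compounds alone.

Compound 1 `Cc1nc(S(C)(=O)=O)ccc1Oc1ncnc(OC2CCN(C(=O)OC(C)(C)C#N)CC2)c1F` gives 92.9 nM in a functional assay on isolated protein for inhibition of Glucose-dependent insulinotropic receptor (Homo sapiens), read by HTRF and cAMP accumulation; on this read-out lower numbers stand for an effect already at smaller amounts and higher numbers for an effect only at larger amounts of compound. Compound 2 `Cc1nc(S(C)(=O)=O)ccc1Oc1ncnc(OC2CCN(C(=O)C(C)(F)F)CC2)c1F` gives 37 nM in the same assay.

Compound 2 has the lowest number of the two measured compounds; its nearest neighbour is compound 1, whose number is higher, and that step, a 2.5-fold lower number from compound 1 to compound 2 (0.40 log units; beyond the scatter), lies beyond the scatter. Compound 3 `CCc1cnc(C(=O)N2CCC(Oc3ncnc(Oc4ccc(S(C)(=O)=O)nc4C)c3F)CC2)nc1` has not yet been measured. It differs from compound 2 at the same position that was changed before: 5-ethylpyrimidin-2-yl in place of 1,1-difluoroethyl on a carbonyl carbon. Going by the values given here, only one measured step bears on this position, a 2.5-fold lower number from compound 1 to compound 2 (0.40 log units; beyond the scatter), and it was modest. Among the compounds with values here, a small fluorinated chain is now replaced by a larger aromatic ring, a change of a different kind, for which there is no direct precedent here. The expectation is therefore a small step in either direction, a 1.1-fold higher number from compound 2 to compound 3 (0.03 log units; within the scatter), with wide uncertainty. Compound 3 is expected to give 40 nM, within a range of 12 nM to 150 nM.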

Compound 3, half-maximal effective concentration: 4.7 nM
Compound 3: middle estimate off by 8.5-fold (0.93 log units), on the high side; measured number below the stated range.
By their numbers in this assay, from the lowest: compound 3; then compound 2; then compound 1.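

In this assay, this position on the carbonyl carbon turns out to accept an aromatic ring, and a much bigger group than the small chains before it: 5-ethylpyrimidin-2-yl in place of 1,1-difluoroethyl gives a 7.9-fold lower number from compound 2 to compound 3 (0.90 log units; beyond the scatter). Going by these compounds alone, measured against 1-cyano-1-methylethoxy, the same ring gives a 20-fold lower number from compound 1 to compound 3 (1.30 log units; beyond the scatter), the only step so far rated large, so the choice of group here can shift the number far more than the first step, a 2.5-fold lower number from compound 1 to compound 2 (0.40 log units; beyond the scatter), suggested. No measurement at hand explains why the ring lowers the number.

Still open, as far as these compounds go, is which part of the new group matters: the ring, its nitrogens or the ethyl. A plain phenyl ring, or a pyrimidin-2-yl without the ethyl, on the same carbonyl would help to separate these parts.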